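Alkyl extension on the aromatic nitrogen: expectation for compound 4

The source may report more compounds than this note shows. Statements on the series, on what has been measured and on what is new or still open speak of the compounds shown alone.

Measured compounds in a functional assay on aorta (strain Wistar) for inhibition, with Thoracic aorta (Rattus norvegicus) as the target; on this read-out lower numbers stand for stronger inhibition and higher numbers for weaker inhibition:
compound 1 `COc1nc(-c2cc3ccccc3o2)cc(-c2cccs2)c1C#N` gives 163000 nM
compound 2 `COc1nc(-c2cc3ccccc3o2)cc(-c2cn(C)c3ccccc23)c1C#N` gives 262000 nM
compound 3 `CCOc1nc(-c2cc3ccccc3o2)cc(-c2cn(C)c3ccccc23)c1C#N` gives 327000 nM

Compound 2 holds the second highest of the three numbers. Its nearest neighbour is compound 3, a gap within the scatter; its furthest is compound 1, also within the scatter. None of the three can be ordered against the others.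

Compound 4 `CCn1cc(-c2cc(-c3cc4ccccc4o3)nc(OC)c2C#N)c2ccccc21` is not yet measured. It differs from compound 2 by methyl in place of hydrogen on a saturated chain carbon bound to an aromatic nitrogen; cut one bond further out, the change reads methyl to ethyl.

Among the measured compounds shown here, one measured step bears on this: the analogous one-carbon extension on a saturated chain carbon bound to an oxygen on an aromatic ring, which gave a 1.2-fold higher number from compound 2 to compound 3 (0.10 log units; within the scatter). That step lies within the scatter. For the measured compounds named here, the present change sits at a different place, so the transfer is indirect, but the only comparable step shows no shift beyond the scatter, and no other step speaks to alkyl length.

The step from compound 2 to compound 4 is therefore expected to be a 1.1-fold higher number from compound 2 to compound 4 (0.03 log units; within the scatter), that is, no change beyond the scatter. Compound 4 is estimated to give 280000 nM, within a range from 140000 nM to 560000 nM.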

Compound 4, half-maximal inhibitory concentration: 299000 nM
Compound 4: the middle estimate sits 1.1-fold (0.03 log units) below what was measured, within the range that was stated.
By their numbers in this assay, from the lowest: compounds 1, 2, 4 and 3 (each within the scatter of the next).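

In this assay, the one-carbon extension on the aromatic nitrogen can now be read directly: a 1.1-fold higher number from compound 2 to compound 4 (0.06 log units; within the scatter). Methyl to ethyl at this place therefore gives no shift beyond the scatter, which the earlier compounds could only suggest indirectly through a change made elsewhere on the molecule. Alongside a 1.2-fold higher number from compound 2 to compound 3 (0.10 log units; within the scatter), this means that the same added methyl has now been seen at two separate places, on a saturated chain carbon bound to an aromatic nitrogen and on one bound to an oxygen on an aromatic ring, and neither step lies beyond the scatter, although nothing available here explains this outcome.

Still open, on these data alone, is whether a longer chain such as butyl or benzyl on the aromatic nitrogen, or a chain there ending in an amine or a carboxylic acid, would give a step beyond the scatter. With both one-carbon steps inside the scatter, these compounds do not yet identify any change at either place that moves the number in this assay.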